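Working notes: from compound 2 to compound 4

The compounds below may be only part of what the source reports. "The series", "measured", "known", "first", "only" and "open" are said of these compounds alone.

Compound 1 (`O=C(Sc1cccnc1C(=O)O)c1cccc(Cl)c1`) 14.8 h
Compound 2 (`O=C(Sc1cccnc1C(=O)O)c1ccc(C(F)(F)F)cc1`) 10.1 h
Compound 3 (`COc1cccc(C(=O)Sc2cccnc2C(=O)O)c1`) 63.7 h

In a physicochemical assay for pharmacokinetics, at pH 8 (a higher number here means that the compound lasts longer, a lower number that the compound disappears faster), compound 2 at 10.1 h and compound 1 at 14.8 h lie within the scatter of each other, while compound 3 at 63.7 h stands beyond the scatter above both.

Compound 4 (`O=C(Sc1cccnc1C(=O)O)c1ccc([N+](=O)[O-])cc1`) has nitro in place of trifluoromethyl on an aromatic carbon of compound 2, para to a large group (nitro in place of trifluoromethyl on an aromatic carbon).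

Among the measured compounds shown here, one measured step bears on this, and only loosely: methoxy in place of chloro on an aromatic carbon brought a 4.3-fold higher number from compound 1 to compound 3 (0.63 log units; beyond the scatter) in the series. That is a different swap, so it shows what size one group change can reach in this assay but gives no firm direction here. For the measured compounds named here, no step involving nitro has been measured. A smaller step than that one is expected, with a slight fall somewhat more likely than a rise. The expected change is a 1.4-fold lower number from compound 2 to compound 4 (0.16 log units; within the scatter) and may well stay within the scatter. Compound 4 is estimated at 7 h with an expected span from 3.5 h to 13 h as its range.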

Compound 4, half-life: 4.7 h
The estimate for compound 4 lay 1.5-fold (0.17 log units) above the measured number, within the range that was stated.
By their numbers in this assay, from the lowest: compound 4; then compounds 2 and 1 (each within the scatter of the next); then compound 3.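

In this assay, nitro in place of trifluoromethyl on an aromatic carbon, para to a large group, gives a clear fall (a 2.1-fold lower number from compound 2 to compound 4 (0.33 log units; beyond the scatter)), so a single group change at this position can move the number beyond the scatter. Among the compounds shown here, the only earlier step (a 4.3-fold higher number from compound 1 to compound 3 (0.63 log units; beyond the scatter)) was a different swap and ran upward, so the series now holds one step in each direction, and a group change on this ring does not fix the direction of the next one. Nothing measured here accounts for the fall.

On these data alone, whether a nitrile or an amine at this same position would follow nitro or stay close to compound 2 remains open. Also open, as far as these compounds go, is whether nitro would lower the number by a similar amount in place of the chloro of compound 1.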